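This account rests on a few compounds, and the source may have more. Where it says the series, first, only, none or still open, it means among the compounds named here.

Working notes, measured in a functional assay on PC-3M cells (Homo sapiens) for antiproliferative activity, read by microscopy, with a stated time of 24 h; a higher number here means a weaker inhibitor, a lower number a stronger inhibitor:
- compound 1 `COc1ccc(-c2c(-c3ccc(OC)cc3)n(Cc3ccccc3)c3ncn(CCCO)c(=N)c23)cc1`: > 20000 nM (a limit of the assay, not a number)
- compound 2 `COc1ccc(Cn2c(-c3ccccc3)c(-c3ccccc3)c3c(=N)n([C@H]4CC[C@H](O)CC4)cnc32)cc1`: 160 nM; 158 nM (2 entries)

Compound 1 has no numerical value and stands only at a limit, > 20000 nM, in this assay. The repeat entries for compound 2 agree closely (the several entries of compound 2 in this assay, 160 nM; 158 nM (2 entries)), so that compound gives a firm reading.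

The next step leads to compound 3 `COc1ccc(-c2c(-c3ccc(OC)cc3)n(Cc3ccccc3)c3ncn(C4CCOCC4)c(=N)c23)cc1`, which has oxan-4-yl in place of 3-hydroxypropyl on an aromatic nitrogen of the core of compound 1 (oxan-4-yl in place of 3-hydroxypropyl on an aromatic nitrogen). Going by the values given here, no measured step isolates this change, so the expectation is loose. One anchor is the limit of compound 1. The other anchor is the reading for compound 2 at 160 nM; 158 nM (2 entries), which shows that the series can reach measurable inhibition. A moderate move toward stronger inhibition is expected in this assay, and a second result reported only as a limit remains quite possible. The expected size of the change is an at least 3.3-fold lower number from compound 1 to compound 3 (0.52 log units; beyond the scatter), given the limit on its starting point. The estimated value for compound 3 is 6000 nM, with an expected range from 700 nM to 20000 nM.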

Compound 3, half-maximal inhibitory concentration: > 20000 nM
Compound 3: only a limit was reported; the forecaster's own chance of this, stated with the estimate: 40%; at least 3.3-fold (0.52 log units) between middle value and limit.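

Compound 3 stands at > 20000 nM in this assay, a limit of the assay and not a number; compound 1 also stands only at a limit, and the step between compound 1 and compound 3 cannot be read. The compounds shown leave open whether oxan-4-yl in place of 3-hydroxypropyl on an aromatic nitrogen changes inhibition at all on this shared core.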